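This account rests on a few compounds, and the source may have more. Where it says the series, first, only, none or still open, it means among the compounds named here.

Compounds measured so far in a functional assay on the whole organism with Mus musculus as the target; on this read-out higher numbers stand for an effect only at larger amounts of compound and lower numbers for an effect already at smaller amounts:

- Compound 1 `C1=C(c2ccccc2)CCC(N2CCN(c3ccccn3)CC2)C1` gives 1 mg/kg
- Compound 2 `C1=C(c2cccs2)CCC(N2CCN(c3ccccn3)CC2)C1` gives 9.3 mg/kg
- Compound 3 `C1=C(c2cccs2)CCC(CN2CCN(c3ccccn3)CC2)C1` gives > 30 mg/kg, which is a limit and not a number

Compound 3 therefore has no exact place on the scale of this assay, and it is known from one side only (the limit of > 30 mg/kg in this assay, at which 1 of the 3 values shown sits). The open question is compound 4 (`C1=C(c2ccccc2)CCC(CN2CCN(c3ccccn3)CC2)C1`), which differs from compound 3 by a single change, phenyl in place of thiophen-2-yl on a double-bonded ring carbon. Among the measured compounds shown here, one measured step bears on this, the same exchange run the opposite way, with thiophen-2-yl in place of phenyl (a 9.3-fold higher number from compound 1 to compound 2 (0.97 log units; beyond the scatter)). Carried over in reverse, that step leads one to expect a lower number of similar size in this assay. The support is a single pair, and the starting point is only a limit. The estimated step is an at least 5.0-fold lower number from compound 3 to compound 4 (0.69 log units; beyond the scatter) and remains rough. Compound 4 is expected near 6 mg/kg, with an estimated range from 2 mg/kg to 25 mg/kg.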

Compound 4, dose for half-maximal effect: about 30 mg/kg
Beside the measured number, compound 4's estimate is 5.0-fold (0.70 log units) below it, and the stated range ends below it.
By their numbers in this assay, from the lowest: compound 1; then compound 2; then compound 4.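

In this assay, compound 3 gives > 30 mg/kg, which is a limit of the assay. On this core, phenyl in place of thiophen-2-yl on a double-bonded ring carbon leads to a number no higher from compound 3 to compound 4 (the limit leaves the size open), and the printed values show that compound 4, at about 30 mg/kg, stays far from compound 1, at 1 mg/kg, which also carries phenyl at this place. So the clear difference seen on the core of compound 1 is not confirmed in size on this core, and it cannot be said whether the change acts alike on both: the same change on two cores in this assay, a 9.3-fold higher number (0.97 log units; beyond the scatter) from compound 1 to compound 2 and a number no lower (the limit leaves the size open) from compound 4 to compound 3; the limit leaves it open whether they differ

From the compounds shown here alone, how far compound 3 really lies from compound 4 stays open, since one of the two rests on a limit: the limit of > 30 mg/kg in this assay, at which 1 of the 4 values shown sits. How an amine or a carboxylic acid on this double-bonded ring carbon would read in this assay also remains open.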